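Extending an Ethyl Chain on a Chemokine Receptor Antagonist

This account rests on a few compounds, and the source may have more. Where it says the series, first, only, none or still open, it means among the compounds named here.

Compound 1 `C[C@@H]1CN(c2scnc2-c2nc3ccccc3[nH]2)CCN1C(=O)Cn1cnc2cccnc21` was tested in a functional assay on U2OS cells for antagonist activity at C-X-C chemokine receptor type 3 (Homo sapiens), read by beta-arrestin recruitment (on this read-out higher numbers stand for weaker inhibition and lower numbers for stronger inhibition), and gives 830 nM. Compound 2 `CC[C@@H]1CN(c2scnc2-c2nc3ccccc3[nH]2)CCN1C(=O)Cn1cnc2cccnc21` carries methyl in place of hydrogen on a saturated chain carbon bound to a saturated ring carbon and in this assay gives 604 nM, so the step of a 1.4-fold lower number from compound 1 to compound 2 (0.14 log units; within the scatter). Compound 3 `CCc1ncc(-c2nc(C(F)(F)F)sc2N2CCN(C(=O)Cn3nc(C)nc3C)[C@H](C)C2)cn1` rests on a different core; the difference between the two cores is not broken down here. In this assay compound 3 gives 1430 nM. Compound 4 `CCCc1ncc(-c2nc(C(F)(F)F)sc2N2CCN(C(=O)Cn3nc(C)nc3C)[C@H](C)C2)cn1` carries methyl in place of hydrogen on a saturated chain carbon, two bonds along the chain from an aromatic carbon. This is the same kind of change as that from compound 1 to compound 2, but the place differs: there the carbon was bound to a saturated ring carbon, here it lies two bonds along the chain from an aromatic carbon. Because the earlier step of a 1.4-fold lower number from compound 1 to compound 2 (0.14 log units; within the scatter) stayed within the scatter, a similarly small step is expected, a 1.3-fold lower number from compound 3 to compound 4 (0.11 log units; within the scatter). Compound 4 is therefore estimated at 1100 nM in this assay, between 500 nM and 2500 nM.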

Compound 4, half-maximal inhibitory concentration: 258 nM
Beside the measured number, compound 4's estimate is 4.3-fold (0.63 log units) above it; the measured number lies below the stated range.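

The same methyl does not give a step of fixed size in this assay: on the second core, the change from ethyl to propyl in the 2-ethylpyrimidin-5-yl group gives a 5.5-fold lower number from compound 3 to compound 4 (0.74 log units; beyond the scatter). Set beside the earlier step, the effect of this change therefore cannot be carried from one core to the other at the same size: the same change on two cores in this assay, a 1.4-fold lower number (0.14 log units; within the scatter) from compound 1 to compound 2 and a 5.5-fold lower number (0.74 log units; beyond the scatter) from compound 3 to compound 4, 4.0-fold (0.61 log units) apart, beyond the scatter of two such steps With one pair per core and the methyl in a different place in each, these compounds do not show whether the core or the place accounts for the gap.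

On these data alone, it remains open how a butyl chain or a cyclopropyl ring would compare with the propyl of compound 4. As far as these compounds go, whether the same step would hold on further cores is also open.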